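This account rests on a few compounds, and the source may have more. Where it says the series, first, only, none or still open, it means among the compounds named here.

In an assay on brain with Translocator protein (Rattus norvegicus) as the target (on this read-out lower numbers stand for stronger inhibition and higher numbers for weaker inhibition), compound 2, with the structure `CCCN(CCC)C(=O)c1c(CN(CC)Cc2ccccc2)nc2ccccc2c1-c1ccccc1`, gives 456 nM. Compound 3, with the structure `CCN(Cc1ccccc1)Cc1nc2ccccc2c(-c2ccccc2)c1C(=O)N(C)c1ccc(Cl)cc1`, differs from it only at the amide: it gives 2480 nM, and the step of a 5.4-fold higher number from compound 2 to compound 3 (0.74 log units; beyond the scatter) is a modest loss. Compound 1, with the structure `Cc1nc2ccccc2c(-c2ccccc2)c1C(=O)N(C)c1ccccc1`, reaches only the limit of the measurement, > 10000 nM, which is a boundary of the assay rather than a number. Among the two numbers that exist, compound 3 therefore stands as the higher, with compound 2 beneath it, while compound 1 sits at the limit of > 10000 nM in this assay, at which 1 of the 3 values shown sits.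

Compound 4, with the structure `CCN(Cc1ccccc1)Cc1nc2ccccc2c(-c2ccccc2)c1C(=O)N(C)c1ccccc1`, is derived from compound 3 by the change (hydrogen in place of chloro on an aromatic carbon). Among the measured compounds shown here, no measured pair shows this chloro-to-hydrogen exchange, so the only step known, the one from compound 2 to compound 3, concerns the amide nitrogen substituents and not the ring substituent. Compound 1 shares the methyl(phenyl)carbamoyl of compound 4 but has a methyl rather than the longer side chain, and it gives only a limit, which says little. A small change is expected; the step of a 1.0-fold higher number from compound 3 to compound 4 (0.00 log units; within the scatter) is estimated to remain within the scatter. For compound 4 a value of 2500 nM is expected, within the range 900 nM to 7000 nM.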

Compound 4, half-maximal inhibitory concentration: 1320 nM
Compound 4: the middle estimate sits 1.9-fold (0.28 log units) above what was measured; measured number inside the range.
By their numbers in this assay, from the lowest: compound 2; then compounds 4 and 3 (each within the scatter of the next). At a limit, above all of these: compound 1.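

Putting hydrogen in place of chloro on the aromatic carbon para to a large group gives a 1.9-fold lower number from compound 3 to compound 4 (0.27 log units; within the scatter), so in this assay these two compounds cannot be told apart and this position tolerates either atom. With the chloro gone, the amide can also be compared on a plain phenyl: a 2.9-fold higher number from compound 2 to compound 4 (0.46 log units; beyond the scatter) shows that the dipropylamino amide keeps its advantage without any chlorine in the comparison. With benzyl(ethyl)amino in place of hydrogen on the saturated chain carbon, the side chain goes with an at least 7.5-fold lower number from compound 1 to compound 4 (0.87 log units; beyond the scatter), a step that starts from a limit of the assay and gives only a minimum size, and that limit reads: the limit of > 10000 nM in this assay, at which 1 of the 4 values shown sits.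

From the compounds shown here alone, it remains open whether a larger or different group at the same para place, such as methoxy, an amine or a carboxylic acid, would shift the number beyond the scatter. Also open, going by these compounds, is how a longer chain on the amide nitrogen, such as dibutylamino, would compare with the dipropylamino of compound 2.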